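This account rests on a few compounds, and the source may have more. Where it says the series, first, only, none or still open, it means among the compounds named here.

Compound 1 `ClCc1ccc(Cn2cnc3c(Cl)ncnc32)cc1`: in a functional assay on IGROV-1 cells (Homo sapiens) for cytotoxicity, read by sulforhodamine B assay, with a stated time of 48 h (on this read-out lower numbers stand for higher toxicity in this test and higher numbers for lower toxicity in this test), compound 1 reaches only the limit > 100000 nM, which is a limit of the test and not a number.
Compound 2 `ClCc1ccccc1Cn1cnc2c(Cl)nc(Cl)nc21`: in this assay compound 2 gives 7070 nM.
Compound 3 `ClCc1cccc(Cn2cnc3ncnc(Cl)c32)c1`: in this assay compound 3 gives 5880 nM.

Among these, compound 3 has the lowest of the two real numbers, but its nearest neighbour, compound 2, lies within the usual scatter of it, so the two cannot be told apart. The limit of compound 1 is described by the limit of > 100000 nM in this assay, at which 1 of the 3 values shown sits, and gives no number to compare.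

The next compound, compound 4 `ClCc1cccc(Cn2cnc3nc(Cl)nc(Cl)c32)c1`, has not yet been measured in this assay. It differs from compound 3 in one place: chloro in place of hydrogen on an aromatic carbon. The new chloro sits between two ring nitrogen atoms, meta to a chloro group and to a fused ring, and para to a fused ring.

Within the data shown here, no single-change step between measured compounds exists here, so the size of this change is not known from data. The step from compound 3 to compound 4 is expected to be small, a 1.2-fold lower number from compound 3 to compound 4 (0.07 log units; within the scatter), not clearly beyond the scatter in either direction. For compound 4 the estimate in this assay is 5000 nM, with a range from 1800 nM to 15000 nM.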

Compound 4, concentration lethal to 50% of the cells: 55000 nM
The estimate for compound 4 lay 11-fold (1.04 log units) below the measured number, and the stated range ends below it.
By their numbers in this assay, from the lowest: compounds 3 and 2 (each within the scatter of the next); then compound 4. At a limit, above all of these: compound 1.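

In this assay, among these compounds, the one single-change pair so far gives a 9.4-fold higher number from compound 3 to compound 4 (0.97 log units; beyond the scatter), and this step lies beyond the scatter. Among the compounds shown here, a chloro in place of hydrogen on this aromatic carbon, between two ring nitrogen atoms, therefore goes with lower toxicity in this test, so this position is not indifferent to what it carries, as the earlier compounds could not show. Nothing measured here explains why this single added chlorine atom has this effect.

Going by these compounds, what an amine or a methoxy group would do on this same carbon remains open, so it is unclear whether the shift belongs to chloro itself or would follow any replacement of hydrogen here. Also open, on these data alone, is whether the same change would give a step of similar size in compounds that differ from compound 3 elsewhere.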